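The source may report more compounds than this note shows. Statements on the series, on what has been measured and on what is new or still open speak of the compounds shown alone.

Measured in a physicochemical assay for solubility, read by LC-MS, in phosphate buffer, with a stated time of 24 h, at pH 7.4; a lower number here means a less soluble compound, a higher number a more soluble compound:
- Compound 1 `COCCC(=O)Nc1cnc(NCc2c(F)ccc3c2CCO3)n2cnnc12`: 980000 nM
- Compound 2 `CN(c1ccn(C)n1)c1cnc(NCc2c(F)ccc3c2CCO3)n2cnnc12`: 130000 nM
- Compound 3 `O=C(Nc1cnc(NCc2c(F)ccc3c2CCO3)n2cnnc12)c1cccnc1`: 12000 nM

Compound 3 has the lowest of these three numbers, and its gaps to both others lie beyond the scatter. Compound 4 `O=C1CC2(CC2)CN1c1cnc(NCc2c(F)ccc3c2CCO3)n2cnnc12` has not yet been measured. Its structure differs from that of compound 3 as follows: a group of 8 heavy atoms (6 carbon, 1 nitrogen, 1 oxygen; one three-membered non-aromatic ring of carbon only, one five-membered non-aromatic ring with 1 hetero atom) in place of a group of 9 heavy atoms (6 carbon, 2 nitrogen, 1 oxygen; one six-membered aromatic ring with 1 hetero atom), on an aromatic carbon. The ((pyridin-3-yl)carbonyl)amino group therefore leaves. Going by the values given here, three measured steps bear on this place. The two that end at compound 3 are large: an 82-fold lower number from compound 1 to compound 3 (1.91 log units; beyond the scatter) and an 11-fold lower number from compound 2 to compound 3 (1.03 log units; beyond the scatter). The third is modest: a 7.5-fold lower number from compound 1 to compound 2 (0.88 log units; beyond the scatter). Neither compound 1 nor compound 2 carries the pyridin-3-yl ring, and compound 4 lacks it too, so a rise is expected. Among the compounds with values here, no measured compound carries the entering group, which leaves the size uncertain. A rise smaller than the largest measured step seems most likely. The expected change is a 5.0-fold higher number from compound 3 to compound 4 (0.70 log units; beyond the scatter). For compound 4 the estimated value is 60000 nM, with an expected range from 15000 nM to 250000 nM.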

Compound 4, solubility: 130000 nM
Compound 4: middle estimate off by 2.2-fold (0.34 log units), on the low side, and the stated range covers the measured number.
By their numbers in this assay, from the lowest: compound 3; then compounds 2 and 4 (each within the scatter of the next); then compound 1.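

In this assay, a group with a three-membered ring of carbon only and a five-membered non-aromatic ring replaces the ((pyridin-3-yl)carbonyl)amino group on this aromatic carbon, giving an 11-fold higher number from compound 3 to compound 4 (1.03 log units; beyond the scatter), so a third group without the pyridin-3-yl ring now stands apart from compound 3. The step to this group from the methyl(1-methyl-1H-pyrazol-3-yl)amino group is no change at the digits printed from compound 2 to compound 4 (within the scatter), so an aromatic five-membered ring and this non-aromatic pair of rings are not told apart here. The ((2-methoxyethyl)carbonyl)amino group still stands apart, with a 7.5-fold lower number from compound 1 to compound 4 (0.88 log units; beyond the scatter); nothing at hand explains these steps.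

The compounds shown leave open whether the pyridin-3-yl ring itself or its carbonyl-amino link sets compound 3 apart, a question that a phenyl ring on the same carbonyl carbon would address. Going by these compounds, how a morpholine on this aromatic carbon would compare also remains open.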